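This account rests on a few compounds, and the source may have more. Where it says the series, first, only, none or still open, it means among the compounds named here.

Compound 1 `Cc1ccccc1C(=O)Nc1cc(Cl)ccn1`: 12.5 ug/mL
Compound 2 `Cc1c(F)cccc1C(=O)Nc1cc(Cl)ccn1`: 12.5 ug/mL
Compound 3 `Cc1c(C(=O)Nc2ccccn2)ccc(F)c1F`: 25 ug/mL

In a physicochemical assay for solubility, read by nephelometry, measured as kinetic solubility, at pH 6.5, tested at 10 mg/mL (on this read-out higher numbers stand for higher solubility and lower numbers for lower solubility), compound 1 gives 12.5 ug/mL, level with compound 2 at 12.5 ug/mL, while compound 3 at 25 ug/mL lies within the usual scatter of both. Compound 4 `Cc1ccnc(NC(=O)c2ccccc2C)c1` differs from compound 1 by one swap, methyl in place of chloro on an aromatic carbon. Going by the values given here, the only measured single change is a different one, fluoro in place of hydrogen on an aromatic carbon, and no change at the digits printed from compound 1 to compound 2 (within the scatter). Among the compounds with values here, no measurement yet tests the swap of chloro itself, so this is weak guidance. The expected change is small, with nothing beyond the scatter: a 1.4-fold higher number from compound 1 to compound 4 (0.16 log units; within the scatter). The estimated value for compound 4 is 18 ug/mL, with an expected range from 6 ug/mL to 50 ug/mL.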

Compound 4, solubility: 25 ug/mL
For compound 4 the middle estimate is 1.4-fold (0.14 log units) below the measured one, and the stated range covers the measured number.
By their numbers in this assay, from the lowest: compounds 1, 2, 3 and 4 (each within the scatter of the next).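

In this assay the first direct test of this position, methyl in place of chloro on the carbon opposite the ring nitrogen, gives a 2.0-fold higher number from compound 1 to compound 4 (0.30 log units; within the scatter). At this place, then, one single-atom group can stand in for the other without a step beyond the usual scatter. No measurement here bears on the cause of this result.

As far as these compounds go, what an amine, a methoxy group or a carboxylic acid would do at this place stays open. So does whether the methyl result holds alongside the fluoro of compound 2.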